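The source may hold more compounds than are shown below. What is called first, only, known or untested is meant among the compounds shown, and "the series" means these compounds.

Measured so far:
compound 1 `CN(C)C(=O)c1cccnc1NCCCN1CCN(c2ccccc2)CC1` — 6.31 nM
compound 2 `CN(C)C(=O)c1cccnc1NCCCN1CCN(c2ccccc2C#N)CC1` — 2 nM

In a functional assay for antagonist activity at Alpha-1A adrenergic receptor (Oryctolagus cuniculus) (on this read-out higher numbers stand for weaker binding and lower numbers for tighter binding), compound 2 holds the lowest of the two numbers; its nearest neighbour is compound 1, and the step of a 3.2-fold lower number from compound 1 to compound 2 (0.50 log units; beyond the scatter) is the only measured one in the series, a modest move from a hydrogen to a cyano on an aromatic carbon.

Compound 3 `CN(C)C(=O)c1cccnc1NCCCN1CCN(c2ccccc2O)CC1` is the next candidate. The change is hydroxy in place of cyano on an aromatic carbon; the group sits ortho to a large group on the six-membered aromatic ring of carbon only. Going by the values given here, no measured step covers a hydroxy here, and the one step available only shows that a cyano improved on a hydrogen at this position. On these data alone, whether a hydroxy holds that gain is unknown, so the expected step of a 2.0-fold higher number from compound 2 to compound 3 (0.30 log units; within the scatter) is set as small, leaning toward a slightly higher number and plausibly within the scatter. The estimate for compound 3 in this assay is 4 nM, with a range from 1.5 nM to 12 nM.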

Compound 3, dissociation constant: 5.01 nM
Compound 3: the middle estimate sits 1.3-fold (0.10 log units) below what was measured, and the stated range covers the measured number.
By their numbers in this assay, from the lowest: compound 2; then compounds 3 and 1 (each within the scatter of the next).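

In this assay this aromatic carbon proves sensitive to which group it carries: replacing cyano with hydroxy gives a 2.5-fold higher number from compound 2 to compound 3 (0.40 log units; beyond the scatter) and so gives up the gain that cyano showed over hydrogen. Set against hydrogen, hydroxy gives a 1.3-fold lower number from compound 1 to compound 3 (0.10 log units; within the scatter) and does not separate from it, so among the three groups at this position, only cyano stands apart, and a substituent here does not in itself bring a lower number. Nothing at hand accounts for the difference between cyano and hydroxy.

Still open, on these data alone, is whether other groups at this carbon, such as a methoxy, a chlorine or an amine, would side with cyano or with hydroxy. Also open, as far as these compounds go, is whether the cyano gain would hold with a longer chain in place of the present one.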